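Adding a Nitrile to Compound 1: An Expected Step

The source may hold more compounds than are shown below. What is called first, only, known or untested is meant among the compounds shown, and "the series" means these compounds.

Compound 1 `O=C(Nc1ccccc1)C1CCN(C/C=C/c2ccccc2)CC1` is the starting point. In a functional assay on HepG2 cells (Homo sapiens) for inhibition, read by MTT assay, with a stated time of 72 h (on this read-out lower numbers stand for stronger inhibition and higher numbers for weaker inhibition), compound 1 gives 90900 nM, the highest of the three numbers measured here; compound 2 `O=C(Nc1cccc(F)c1)C1CCN(C/C=C/c2ccccc2)CC1` gives 51100 nM and compound 3 `O=C(Nc1ccc(F)c(Br)c1)C1CCN(C/C=C/c2ccccc2)CC1` gives 8190 nM. Compound 4 `N#Cc1ccc(NC(=O)C2CCN(C/C=C/c3ccccc3)CC2)cc1` differs from compound 1 by cyano in place of hydrogen on an aromatic carbon. Going by the values given here, two measured steps bear on this: a 1.8-fold lower number from compound 1 to compound 2 (0.25 log units; within the scatter), and an 11-fold lower number from compound 1 to compound 3 (1.05 log units; beyond the scatter). Both replace hydrogen on the same ring with something larger, yet neither introduces a cyano group, and only the two-group change moved the number beyond the scatter. The expected step is therefore modest, a 2.3-fold lower number from compound 1 to compound 4 (0.36 log units; beyond the scatter), toward stronger inhibition. Compound 4 is estimated at 40000 nM, within a range of 15000 nM to 100000 nM.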

Compound 4, half-maximal inhibitory concentration: 38300 nM
For compound 4 the middle estimate is 1.0-fold (0.02 log units) above the measured one; the range from low to high includes it.
By their numbers in this assay, from the lowest: compound 3; then compounds 4, 2 and 1 (each within the scatter of the next, the first and the last beyond it).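

A single cyano group on this ring carbon, para to a large group, is enough to move the number beyond the scatter in this assay (a 2.4-fold lower number from compound 1 to compound 4 (0.38 log units; beyond the scatter)). Its result still cannot be separated from that of the fluoro ring (a 1.3-fold lower number from compound 2 to compound 4 (0.13 log units; within the scatter)), and the 3-bromo-4-fluorophenyl ring keeps a clear lead (a 4.7-fold higher number from compound 3 to compound 4 (0.67 log units; beyond the scatter)). No available measurement explains these differences.

The compounds shown leave open whether an amine or a carboxylic acid on this same carbon would lower the number further. They also leave open how a lone bromo would compare.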